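Propargylamine series: swapping the aryl group on the thioether chain

The source may hold more compounds than are shown below. What is called first, only, known or untested is meant among the compounds shown, and "the series" means these compounds.

Measured so far:
compound 1, `C#CCNC1CCc2c(SCCc3ccc(Br)cc3)cccc21`, 85300 nM
compound 2, `C#CCNC1CCc2c(SCc3ccc(C(F)(F)F)cc3)cccc21`, 9680 nM

Working notes. In an assay on isolated protein for inhibition of Amine oxidase [flavin-containing] B (Homo sapiens) (on this read-out higher numbers stand for weaker inhibition and lower numbers for stronger inhibition), compound 1 gives 85300 nM, the higher of the two numbers in hand; compound 2 gives 9680 nM, a lower number, and the two values lie beyond the scatter. Going by the values given here, the two compounds differ in more than one place, so no single step between them can be read off.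

Compound 3, `C#CCNC1CCc2c(SCCc3cccc(OC)c3)cccc21`, is the next compound for this assay. It differs from compound 1 by 3-methoxyphenyl in place of 4-bromophenyl on a saturated chain carbon, two bonds along the chain from a sulfur. The core and the chain linking the sulfur to the aryl group are kept; only the aryl substituent pattern changes.

Nothing measured in the series isolates the effect of this change. With compound 1 standing at 85300 nM, the expectation for compound 3 is a step of at most moderate size, likely toward a lower number, but a result within the scatter cannot be ruled out: a 1.6-fold lower number from compound 1 to compound 3 (0.19 log units; within the scatter) is the step the estimate means. Compound 3 is therefore expected to give 55000 nM, with a range from 15000 nM to 200000 nM.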

Compound 3, half-maximal inhibitory concentration: 28700 nM
Estimate against measurement, compound 3: 1.9-fold (0.28 log units) above, and the stated range covers the measured number.
By their numbers in this assay, from the lowest: compound 2; then compound 3; then compound 1.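

In this assay, 3-methoxyphenyl in place of 4-bromophenyl on a saturated chain carbon, two bonds along the chain from a sulfur, gives a 3.0-fold lower number from compound 1 to compound 3 (0.47 log units; beyond the scatter) with the core and chain held fixed. Going by these compounds alone, this is the first step that can be read at a single place, and it shows that the aryl group at this position alone can move the number beyond the scatter, which the multi-place contrast between compound 1 and compound 2 could not show. The step changes the substituent and its location on the aryl group together, so it does not separate the two, and no independent data on hand bear on the reason for the change.

Still open, on these data alone, is whether the lower number follows the methoxy group or its location, a question that 4-methoxyphenyl or 3-bromophenyl on the same chain would address. Also open, as far as these compounds go, is how the number responds to an amine or a carboxylic acid on the aryl group, or to a longer chain between the sulfur and the aryl group.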